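This account rests on a few compounds, and the source may have more. Where it says the series, first, only, none or still open, it means among the compounds named here.

Working notes on the series built on the core of compound 1 (`O=C(O)CC/C=C\CC1COC(c2ccc(C(F)(F)F)cc2)OC1c1cccnc1`). In a functional assay for inhibition, with Homo sapiens as the target (a higher number here means weaker binding, a lower number tighter binding), compound 1 gives 1780 nM. Compound 3 (`O=C(O)CC/C=C\CC1COC(c2ccc3ccccc3c2)OC1c1cccnc1`) gives 1780 nM, so these two together hold the highest number of the three measured. Compound 2 (`O=C(O)CC/C=C\CC1COC(c2cccnc2)OC1c1cccnc1`) gives 759 nM, the lowest number.

The next compound is compound 4 (`O=C(O)CC/C=C\CC1COC(c2cccc3ccccc23)OC1c1cccnc1`), with naphthalen-1-yl in place of 4-(trifluoromethyl)phenyl on a saturated ring carbon, between two ring oxygen atoms: naphthalen-1-yl in place of 4-(trifluoromethyl)phenyl on a saturated ring carbon.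

Two measured changes at this same place bear on it. The closer one, with naphthalen-2-yl entering, shows no change at the digits printed from compound 1 to compound 3 (within the scatter). With pyridin-3-yl entering, the result is a 2.3-fold lower number from compound 1 to compound 2 (0.37 log units; beyond the scatter), and the matching comparison of the two entering groups is a 2.3-fold higher number from compound 2 to compound 3 (0.37 log units; beyond the scatter). For the measured compounds named here, no measured compound carries naphthalen-1-yl, so the closest guide is a single naphthalen-2-yl example.

No step beyond the scatter is therefore expected in this assay, and no direction is favoured with any confidence. The expected change is a 1.1-fold lower number from compound 1 to compound 4 (0.05 log units; within the scatter). For compound 4 the estimated value is 1600 nM, with an expected range of 750 nM to 3400 nM.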

Compound 4, dissociation constant: 631 nM
Beside the measured number, compound 4's estimate is 2.5-fold (0.40 log units) above it, outside the stated range (below it).
By their numbers in this assay, from the lowest: compounds 4 and 2 (each within the scatter of the next); then compounds 1 and 3 (each within the scatter of the next).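

In this assay, for the compounds shown here, the point of attachment of the naphthalene proves to matter at this saturated ring carbon, a distinction the earlier compounds could not show: going from naphthalen-2-yl to naphthalen-1-yl gives a 2.8-fold lower number from compound 3 to compound 4 (0.45 log units; beyond the scatter). Naphthalen-2-yl had not separated from 4-(trifluoromethyl)phenyl, whereas naphthalen-1-yl does, with a 2.8-fold lower number from compound 1 to compound 4 (0.45 log units; beyond the scatter). A group with only carbon in its rings also reaches the range of the pyridin-3-yl compound, since a 1.2-fold lower number from compound 2 to compound 4 (0.08 log units; within the scatter) leaves those two unseparated, so among these compounds a ring nitrogen in this group is not needed for the lowest numbers, and no measurement at hand accounts for any of these differences.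

The compounds shown leave open whether a methoxy or fluoro group on the naphthalen-1-yl ring, or a saturated cyclohexyl group at this carbon, would hold or move the number. They also leave open whether the gap between the two naphthalene attachments survives when the 5-carboxypent-2-en-1-yl chain is replaced by a longer chain, or when the pyridin-3-yl group gives way to a phenyl group.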